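The compounds below may be only part of what the source reports. "The series", "measured", "known", "first", "only" and "open" are said of these compounds alone.

Compound 1 `O=[N+]([O-])c1ccccc1CNc1cc(C(F)(F)F)cc2[nH]ncc12`: 76%
Compound 2 `O=[N+]([O-])c1ccccc1CNc1cc(Br)cc2[nH]ncc12`: 83%
Compound 3 `O=[N+]([O-])c1ccc(O)cc1CNc1cc(Br)cc2[nH]ncc12`: 98%

These numbers come from an assay for inhibition of Indoleamine 2,3-dioxygenase 1 (Homo sapiens), with stated times of 10 min and 60 min, tested at 100 uM; a higher number here means a stronger effect of the compound at the concentration tested, a lower number a weaker effect. Compound 2 stands second highest of the three: compound 1 lies within the scatter of it, with a number 7 percentage points higher from compound 1 to compound 2 (within the scatter), while compound 3 stands higher, with a number 15 percentage points higher from compound 2 to compound 3 (beyond the scatter). Compound 4 `N#Cc1cc(NCc2ccccc2[N+](=O)[O-])c2cn[nH]c2c1` has not yet been measured. It differs from compound 2 in one place: cyano in place of bromo on an aromatic carbon. Within the data shown here, only one measured step concerns this same aromatic carbon, the change from trifluoromethyl to bromo, which gave a number 7 percentage points higher from compound 1 to compound 2 (within the scatter), a step within the scatter. Nothing measured shows how a cyano group at this place behaves. Compound 4 is therefore expected to stay within the scatter of its parent, the estimated step being a number 5 percentage points lower from compound 2 to compound 4 (within the scatter). The estimate for compound 4 is 78%, ranging from 55% to 95%.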

Compound 4, a percentage reported as inhibition, at one concentration (the size of the read-out at that concentration, not a potency): 17%
For compound 4 the middle estimate is 61 percentage points above the measured one; the measured number lies below the stated range.
By their numbers in this assay, from the lowest: compound 4; then compounds 1 and 2 (each within the scatter of the next); then compound 3.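

Among these compounds, this position proved far less tolerant than the earlier compounds suggested: trifluoromethyl and bromo gave numbers within the scatter of each other, yet cyano gives a number 66 percentage points lower from compound 2 to compound 4 (beyond the scatter) and a number 59 percentage points lower from compound 1 to compound 4 (beyond the scatter). The group on this aromatic carbon can therefore largely decide the read-out, which compounds 1 and 2 alone did not reveal. Nothing available explains this loss.

From the compounds shown here alone, whether the loss is specific to cyano remains open; a methyl group, an amine or a carboxylic acid on this carbon could show that. Also open, going by these compounds, is whether the hydroxy group carried by compound 3 would raise the number for compound 4 as well.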